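Shortening a Saturated Side Chain on Compound 1

The source may report more compounds than this note shows. Statements on the series, on what has been measured and on what is new or still open speak of the compounds shown alone.

Among the compounds with values here, compound 1 `CCCCCc1cc2ccccc2nc1-c1cn(-c2ccc(F)cc2)nn1` is one of two compounds measured in a functional assay on U-937 cells (Homo sapiens) for cytotoxicity, read by MTT assay, with a stated time of 24 h (on this read-out lower numbers stand for stronger inhibition and higher numbers for weaker inhibition), where compound 1 gives 67.5 ug/mL, the higher of the two numbers. The other, compound 2 `CCCCCCCCCCn1cc(-c2nc3ccccc3cc2CCCCC)nn1`, gives 18.2 ug/mL. Within the data shown here, the single measured step, a 3.7-fold lower number from compound 1 to compound 2 (0.57 log units; beyond the scatter), concerns the group on the aromatic nitrogen and nothing else. Compound 3 `CCCCc1cc2ccccc2nc1-c1cn(-c2ccc(F)cc2)nn1` has not yet been measured; it differs from compound 1 by hydrogen in place of methyl on a saturated chain carbon, four bonds along the chain from an aromatic carbon. Among the measured compounds shown here, no measured step touches this saturated chain, so nothing in the data shows how trimming it shifts the read-out, and the step from compound 1 to compound 2 bears on it only indirectly, as a sign that the rest of the molecule tolerates change at some sites. The step expected here, a 1.0-fold higher number from compound 1 to compound 3 (0.00 log units; within the scatter), is none beyond the scatter. Compound 3 is therefore estimated to give about 68 ug/mL in this assay, within a range from 34 ug/mL to 140 ug/mL.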

Compound 3, half-maximal inhibitory concentration: 66.2 ug/mL
For compound 3 the middle estimate is 1.0-fold (0.01 log units) above the measured one, within the range that was stated.
By their numbers in this assay, from the lowest: compound 2; then compounds 3 and 1 (each within the scatter of the next).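

Hydrogen in place of methyl on a saturated chain carbon, four bonds along the chain from an aromatic carbon, gives a 1.0-fold lower number from compound 1 to compound 3 (0.01 log units; within the scatter) in this assay as the measured change. Within the data shown here, the only earlier step concerned the group on the aromatic nitrogen, so this is the first reading from the saturated chain, and it shows that losing this one methyl leaves the number within the scatter. No separate measurement bears on the reason for this result.

Going by these compounds, whether a much shorter chain, a longer chain, or a chain carrying an amine or a carboxylic acid would leave the number equally unmoved stays open. Also open, on these data alone, is whether the same change would read alike in compound 2, which carries decyl on the aromatic nitrogen.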